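Swapping a Propyl for a Cyclopropyl on the Amine

This account rests on a few compounds, and the source may have more. Where it says the series, first, only, none or still open, it means among the compounds named here.

Of the compounds shown here, three sharing one core have been measured in an assay on cell membranes for displacement of a labelled ligand from corticotropin-releasing factor receptor 1 (Rattus norvegicus); on this read-out higher numbers stand for weaker inhibition and lower numbers for stronger inhibition. Compound 1 `CCOCC(COCC)Nc1nc(C)nc2c(-c3ccc(OC)cc3C)c(C)nn12` gives 19.3 nM, compound 2 `COCC(COC)Nc1nc(C)nc2c(-c3ccc(OC)cc3C)c(C)nn12` gives 9.7 nM, and compound 3 `CCCN(CCC#N)c1nc(C)nc2c(-c3ccc(OC)cc3C)c(C)nn12` gives 2.16 nM. Compound 3 stands lowest of the three, so it is the strongest inhibitor here: its nearest neighbour is compound 2, and the gap a 4.5-fold lower number from compound 2 to compound 3 (0.65 log units; beyond the scatter); the larger gap an 8.9-fold lower number from compound 1 to compound 3 (0.95 log units; beyond the scatter). The remaining step, a 2.0-fold lower number from compound 1 to compound 2 (0.30 log units; within the scatter), is a change of the ether groups on the amine.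

Compound 4 `COc1ccc(-c2c(C)nn3c(N(CCC#N)C4CC4)nc(C)nc23)c(C)c1` is not yet measured. It differs from compound 3 in one place: cyclopropyl in place of propyl on a nitrogen on an aromatic ring. Among the compounds with values here, none of the measured steps touches this kind of change. The two steps that reach compound 3 replace the whole amine substituent, not just the propyl, and the step from compound 1 to compound 2 alters ether groups that compound 3 and compound 4 do not carry. Within the data shown here, with no direct precedent, the expectation is a step of a 1.2-fold higher number from compound 3 to compound 4 (0.06 log units; within the scatter), that is, nothing beyond the scatter in this assay. Compound 4 is therefore estimated at 2.5 nM in this assay, within a range from 1 nM to 6.5 nM.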

Compound 4, half-maximal inhibitory concentration: 1.88 nM
Beside the measured number, compound 4's estimate is 1.3-fold (0.12 log units) above it; measured number inside the range.
By their numbers in this assay, from the lowest: compounds 4 and 3 (each within the scatter of the next); then compounds 2 and 1 (each within the scatter of the next).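

In this assay, within the data shown here, the only step that touches this group alone is a 1.1-fold lower number from compound 3 to compound 4 (0.06 log units; within the scatter), so at this place on the nitrogen a propyl chain and a cyclopropyl ring of the same three carbons cannot be told apart. The cyclopropyl compound also keeps the clear lead over the two ether-bearing amines that compound 3 showed, with a 5.2-fold lower number from compound 2 to compound 4 (0.71 log units; beyond the scatter) and, larger still, a 10-fold lower number from compound 1 to compound 4 (1.01 log units; beyond the scatter), so these gaps do not depend on the open propyl chain. Nothing available here bears on why the chain and the ring read alike.

Among these compounds, the result covers only two groups of three carbons, so it remains open whether a cyclobutyl ring, a cyclopentyl ring or a longer chain such as butyl on this nitrogen would also stay within the scatter of compound 3. Cyclopropyl also appears here only alongside the 2-cyanoethyl group, so what it would do with a different partner on the same nitrogen, such as a 2-methoxyethyl chain, is equally open.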